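Notes on compound 3: replacing the aromatic group

This account rests on a few compounds, and the source may have more. Where it says the series, first, only, none or still open, it means among the compounds named here.

Measured in a functional assay on Mahlavu cells (Homo sapiens) for antiproliferative activity, read by sulforhodamine B assay, with a stated time of 72 h; a higher number here means a weaker inhibitor, a lower number a stronger inhibitor:
- compound 1 `Nc1nc(N2CCN(C(c3ccccc3)c3ccccc3)CC2)c2ncn([C@@H]3O[C@H](CO)[C@@H](O)[C@H]3O)c2n1`: 7000 nM
- compound 2 `CC(C)c1ccc(Nc2ncnc3c2ncn3[C@@H]2O[C@H](CO)[C@@H](O)[C@H]2O)cc1`: 40000 nM

Compound 2 stands at the higher of the two numbers, with 40000 nM in this assay. Compound 1 is lower at 7000 nM, and the gap between them lies beyond the scatter. Among the measured compounds shown here, with only two numbers, no trend can be read from the series.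

The next compound to be measured is compound 3 `OC[C@H]1O[C@@H](n2cnc3c(NCCC4=CCCCC4)ncnc32)[C@H](O)[C@@H]1O`. Its change from compound 2 is 2-(cyclohex-1-en-1-yl)ethyl in place of 4-isopropylphenyl on a nitrogen on an aromatic ring. In words, 2-(cyclohex-1-en-1-yl)ethyl stands in place of 4-isopropylphenyl on a nitrogen on an aromatic ring. One six-membered aromatic ring of carbon only thus gives way to one six-membered non-aromatic ring of carbon only, and 1 double bond outside aromatic rings enters.

For the measured compounds named here, no measured pair isolates this kind of change, so the expectation is weakly grounded. In this assay, no step beyond the scatter is expected. The estimated step is a 1.8-fold lower number from compound 2 to compound 3 (0.26 log units; within the scatter). For compound 3 the expected value is 22000 nM, with an estimated range of 7000 nM to 60000 nM.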

Compound 3, half-maximal inhibitory concentration: > 100000 nM
Compound 3: no number, only a limit (the forecaster's own chance of this, stated with the estimate: 15%); at least 4.5-fold (0.65 log units) between middle value and limit.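

In this assay compound 3 reads > 100000 nM, which is a limit of the assay and not a number. Among the compounds shown here, this gives the first step at a nitrogen on an aromatic ring: 2-(cyclohex-1-en-1-yl)ethyl in place of 4-isopropylphenyl yields an at least 2.5-fold higher number from compound 2 to compound 3 (0.39 log units; beyond the scatter), so the activity in this assay does respond to the group at this position, and the change to the non-aromatic ring with its double bond does not improve on the 4-isopropylphenyl group. Only a lower bound on the size of this step can be read, and its full size stays unknown: the limit of > 100000 nM in this assay, at which 1 of the 3 values shown sits.

For the compounds shown here, the single step changes the ring, the ethyl chain and the double bond together, so the share of each in the loss remains unresolved, and no cause can be assigned from these compounds. On these data alone, a 2-phenylethyl group on the same nitrogen would keep the ethyl chain with a six-membered aromatic ring of carbon only, and how such a group compares with 4-isopropylphenyl and 2-(cyclohex-1-en-1-yl)ethyl stays open.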